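The compounds below may be only part of what the source reports. "The series", "measured", "known", "first", "only" and "open" are said of these compounds alone.

Working notes on the series. The shared core carries a trimethoxyphenyl group and an alkoxy chain that varies in length. Compound 1 `CCCOc1c(-c2cc(OC)c(OC)c(OC)c2)oc2ccccc2c1=O` gives 5700 nM in a functional assay on LNCaP cells (Homo sapiens) for antiproliferative activity, read by WST assay, with a stated time of 3 days; on this read-out lower numbers stand for stronger inhibition and higher numbers for weaker inhibition. Compound 2 `CCCCCOc1c(-c2cc(OC)c(OC)c(OC)c2)oc2ccccc2c1=O` gives 15400 nM in this assay, and compound 3 `CCCCCCOc1c(-c2cc(OC)c(OC)c(OC)c2)oc2ccccc2c1=O` gives 19600 nM. Compound 2 stands second highest of the three numbers: it sits nearest to compound 3, within the scatter, and furthest from compound 1, which is the most potent of the three. Lengthening the chain weakens the effect: a 2.7-fold higher number from compound 1 to compound 2 (0.43 log units; beyond the scatter) and a 3.4-fold higher number from compound 1 to compound 3 (0.54 log units; beyond the scatter), whereas a 1.3-fold higher number from compound 2 to compound 3 (0.10 log units; within the scatter).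

Compound 4 `CCCCN(CCCC)CCCCOc1c(-c2cc(OC)c(OC)c(OC)c2)oc2ccccc2c1=O` is the next step from compound 2. The change is dibutylamino in place of methyl on a saturated chain carbon, four bonds along the chain from an oxygen on an aromatic ring. Going by the values given here, no measured step puts a nitrogen into the chain; the steps that bear on it are the chain-lengthening ones above, which were modest and toward higher numbers, and the last of them, from compound 2 to compound 3, stayed within the scatter. The change to compound 4 is far larger than any of those and is not covered by precedent, so the expectation for compound 4 in this assay is a step near the scatter in either direction, with wide uncertainty: a 1.3-fold lower number from compound 2 to compound 4 (0.11 log units; within the scatter). For compound 4 the estimated value is 12000 nM, expected to fall between 3000 nM and 45000 nM.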

Compound 4, half-maximal inhibitory concentration: 7800 nM
Compound 4: the middle estimate sits 1.5-fold (0.19 log units) above what was measured; the range from low to high includes it.
By their numbers in this assay, from the lowest: compounds 1, 4, 2 and 3 (each within the scatter of the next, the first and the last beyond it).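

In this assay, the dibutylamino group is tolerated at this place, on a saturated chain carbon four bonds along the chain from an oxygen on an aromatic ring: the series shows a 2.5-fold lower number from compound 3 to compound 4 (0.40 log units; beyond the scatter), alongside a 2.0-fold lower number from compound 2 to compound 4 (0.30 log units; within the scatter) and a 1.4-fold higher number from compound 1 to compound 4 (0.14 log units; within the scatter). Compound 4 thus goes against the pattern of higher numbers on lengthening the plain alkyl chain, since this much larger nitrogen-bearing end group brings no further rise and reads clearly apart from compound 3 only. No supporting data are available to explain this result.

As far as these compounds go, it remains open whether the nitrogen or the two butyl groups account for the reading of compound 4, a question that a dimethylamino, piperidine or morpholine end group, or a plain alkyl chain of matching length, could address. Also open, from the compounds shown here alone, is how the reading depends on the length of the chain carrying the amine, and whether a shorter linker to the dibutylamino group or a carboxylic acid at the chain end would be tolerated in this assay.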